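Compound 4: removing the methyl from compound 3

A few compounds are considered here, and "the series" means these few. Any claim that something is new, unique, unknown or untested is made for them only; others in the source may bear on it.

Measured in a functional assay on MCF7 cells (Homo sapiens) for antiproliferative activity, read by MTT assay, with a stated time of 48 h; a lower number here means a stronger inhibitor, a higher number a weaker inhibitor:
Compound 1 `COc1cccc(-n2cc(COc3ccc(/C=C/C(C)=O)cc3OC)nn2)c1`: 1800 nM
Compound 2 `COc1cc(/C=C/C(C)=O)ccc1OCc1cn(-c2ccc(NC(=O)c3ccccc3)cc2)nn1`: 86700 nM
Compound 3 `COc1cc(/C=C/C(C)=O)ccc1OCc1cn(-c2ccc(C)cc2)nn1`: > 100000 nM, a limit

Compound 3 stands at the limit of > 100000 nM in this assay, at which 1 of the 3 values shown sits. Compound 4 `COc1cc(/C=C/C(C)=O)ccc1OCc1cn(-c2ccccc2)nn1` has hydrogen in place of methyl on an aromatic carbon. Among the measured compounds shown here, two measured steps bear on this. With 4-methylphenyl in place of 3-methoxyphenyl, the step is an at least 55-fold higher number from compound 1 to compound 3 (1.74 log units; beyond the scatter). With methyl in place of benzamido, the step is an at least 1.1-fold higher number from compound 2 to compound 3 (0.06 log units; that floor lies within the scatter). Neither isolates the methyl itself. Only a modest move to a lower number is expected, leaving compound 4 nearer compound 2 at 86700 nM than compound 1 at 1800 nM. The expected change is an at least 2.0-fold lower number from compound 3 to compound 4 (0.30 log units; that floor lies within the scatter). For compound 4 the estimated value is 50000 nM, with an expected range of 10000 nM to 100000 nM.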

Compound 4, half-maximal inhibitory concentration: > 100000 nM
Compound 4: only a limit was reported (the forecaster's own chance of this, stated with the estimate: 35%); middle value at least 2.0-fold (0.30 log units) from the limit.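

In this assay compound 4 gives > 100000 nM, a limit and not a number, and with compound 3 also at a limit the change from methyl to hydrogen cannot be read: the limit of > 100000 nM in this assay, at which 2 of the 4 values shown sit. Hydrogen in place of methoxy, a change in one place, gives an at least 55-fold higher number from compound 1 to compound 4 (1.74 log units; beyond the scatter), so the lower number of compound 1 goes with its methoxy and needs no methyl to be removed. Hydrogen in place of benzamido gives an at least 1.1-fold higher number from compound 2 to compound 4 (0.06 log units; that floor lies within the scatter), a floor within the scatter.

Open, on these data alone, is whether a hydroxyl or an amine in place of the methoxy of compound 1 holds that lower number.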